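The compounds below may be only part of what the source reports. "The series", "measured", "known", "first", "only" and "open" are said of these compounds alone.

For the measured compounds named here, in an ADME assay on RAW264.7 cells (Mus musculus) for inhibition, read by MTT assay, with a stated time of 72 h, tested at 50 uM (a lower number here means less inhibition of growth, a higher number more inhibition of growth at the concentration tested), compound 2 `COc1ccc(/N=N/C(=N/NC(=O)c2cc(O)c(O)c(O)c2)c2ccccc2)cc1` gives 4.51%, the lower of the two numbers measured so far, while compound 1 `COc1ccccc1/N=N/C(=N/NC(=O)c1cc(O)c(O)c(O)c1)c1ccccc1` gives 46.5%. Compound 3 `O=C(N/N=C(/N=N/c1ccccc1[N+](=O)[O-])c1ccccc1)c1cc(O)c(O)c(O)c1` differs from compound 2 by one change: 2-nitrophenyl in place of 4-methoxyphenyl on a double-bonded nitrogen. Here, 2-nitrophenyl takes the place of 4-methoxyphenyl on a double-bonded nitrogen. Going by the values given here, one measured step bears on that place: a number 42 percentage points lower from compound 1 to compound 2 (beyond the scatter), with 4-methoxyphenyl in place of 2-methoxyphenyl. Among the compounds with values here, it shows that a swap there can move the number a long way, although no nitro-bearing compound has been measured. The entering group's name begins with 2-, like that of the group in compound 1 at 46.5%, so a rise is expected, though one pair is only a loose guide. The expected upward move is estimated as a number 25.5 percentage points higher from compound 2 to compound 3 (beyond the scatter). For compound 3 the estimate is 30%, with an expected range of 8% to 55%.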

Compound 3, percent growth inhibition at one concentration: 2.11%
For compound 3 the middle estimate is 27.9 percentage points above the measured one; the measured number lies below the stated range.
By their numbers in this assay, from the lowest: compounds 3 and 2 (each within the scatter of the next); then compound 1.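

In this assay the change to 2-nitrophenyl gives a number 2.4 percentage points lower from compound 2 to compound 3 (within the scatter), so at this place on a double-bonded nitrogen the 2-nitrophenyl and 4-methoxyphenyl groups cannot be told apart. With nitro in place of methoxy on an aromatic carbon, the other pair gives a number 44.4 percentage points lower from compound 1 to compound 3 (beyond the scatter) and shows that a name beginning with 2- does not by itself bring the higher number of compound 1; what counts here is the group itself, methoxy rather than nitro, and not only where it sits. No measurement offered here explains this difference.

Still open, going by these compounds, is whether the higher number is special to 2-methoxyphenyl or would also appear with 2-ethoxyphenyl or 2-aminophenyl. On these data alone, it is also open what 4-nitrophenyl would give at this place, which would complete the comparison of the two groups at both named sites.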